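A Single Methyl on the Amide Chain of Compound 2

The compounds below may be only part of what the source reports. "The series", "measured", "known", "first", "only" and "open" are said of these compounds alone.

In an ADME assay on MT4 cells (Homo sapiens) for cytotoxicity, read by MTT assay (a higher number here means that more compound is tolerated, a lower number that less compound is tolerated), compound 1 (`Cc1cc(C)cc(S(=O)(=O)c2c(C(=O)NC(C)c3ccccc3O)[nH]c3ccc(Cl)cc23)c1`) gives 21800 nM. Compound 2 (`Cc1cc(C)cc(S(=O)(=O)c2c(C(=O)NCC(=O)NCc3ccccc3O)[nH]c3ccc(Cl)cc23)c1`) is reported only as a limit of the assay, > 47300 nM. Its true position is therefore open, and it gives no exact starting number.

Compound 3 (`Cc1cc(C)cc(S(=O)(=O)c2c(C(=O)NC(C)C(=O)NCc3ccccc3O)[nH]c3ccc(Cl)cc23)c1`) departs from compound 2 by one change, methyl in place of hydrogen on a saturated chain carbon bound to an amide-type nitrogen and a carbonyl carbon.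

Within the data shown here, the only measured step that bears on this is an at least 2.1-fold higher number from compound 1 to compound 2 (0.33 log units; beyond the scatter). That step lies beyond the scatter, but it exchanges the whole group on the amide-type nitrogen, and its size is open-ended. Among the measured compounds shown here, no measured step isolates a methyl in place of hydrogen. In this assay, no step beyond the scatter is therefore expected, and compound 3 may again be reported only as a limit. The estimated step is an at least 1.0-fold lower number from compound 2 to compound 3 (0.02 log units; that floor lies within the scatter). For compound 3 the expected value is 45000 nM, with an estimated range of 22000 nM to 90000 nM.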

Compound 3, half-maximal cytotoxic concentration: 14400 nM
Beside the measured number, compound 3's estimate is 3.1-fold (0.49 log units) above it; the measured number lies below the stated range.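

In this assay, a single methyl on the saturated chain carbon bound to an amide-type nitrogen and a carbonyl carbon brings an at least 3.2-fold lower number from compound 2 to compound 3 (0.51 log units; beyond the scatter) and this is the only step shown that isolates one such small change, so even this one added carbon can move the number beyond the scatter. Compound 2 is held only as a limit of the assay, which gives that step a floor and no upper end: the limit of > 47300 nM in this assay, at which 1 of the 3 values shown sits. The exchange of the larger group reads a 1.5-fold lower number from compound 1 to compound 3 (0.18 log units; within the scatter) and stays within the scatter, whereas an at least 2.1-fold higher number from compound 1 to compound 2 (0.33 log units; beyond the scatter) lay beyond it, so the separation seen for the chain without the methyl is not seen once the methyl is present.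

From the compounds shown here alone, the true size of the methyl step stays open, as does how far the number would move with a larger group such as ethyl, isopropyl or benzyl on that chain carbon. The compounds shown also leave open whether a hydroxymethyl group or an aminomethyl group in the same place would follow methyl or would leave the number at the level of the chain without it.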